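The compounds below may be only part of what the source reports. "The series", "measured", "known", "first", "only" and "open" are said of these compounds alone.

In an ADME assay (liver) for metabolic stability, with Liver microsome (Homo sapiens) as the target, using microsomes and NADPH, with a stated time of 30 min, tested at 1 uM (a lower number here means slower removal, a higher number faster removal of the compound), compound 1 `COCC#Cc1cc(C(O)(C(F)(F)F)C(F)(F)F)cnc1N1CCN(S(=O)(=O)c2ccc(N)nc2)CC1` gives 15 mL.min-1.g-1 while compound 2 `Nc1ccc(S(=O)(=O)N2CCN(c3ncc(C(O)(C(F)(F)F)C(F)(F)F)cc3-c3ccccc3O)CC2)cn1` gives 22 mL.min-1.g-1 and compound 3 `Nc1ccc(S(=O)(=O)N2CCN(c3ncc(C(O)(C(F)(F)F)C(F)(F)F)cc3-c3ccc4scnc4c3)CC2)cn1` gives 39 mL.min-1.g-1 on the same scale. Compound 3 stands within the scatter of compound 2 and above compound 1 by more than the scatter. The change to compound 4 `Nc1ccc(S(=O)(=O)N2CCN(c3ncc(C(O)(C(F)(F)F)C(F)(F)F)cc3-c3cc4ccccc4s3)CC2)cn1` is 1-benzothiophen-2-yl in place of 1,3-benzothiazol-5-yl on an aromatic carbon and it falls on the same aromatic carbon as all three measured steps. Those steps show a 1.5-fold higher number from compound 1 to compound 2 (0.17 log units; within the scatter) and a 2.6-fold higher number from compound 1 to compound 3 (0.41 log units; beyond the scatter) as exchanges of the 3-methoxyprop-1-yn-1-yl group. Closest is the step between two ring groups, where a 1.8-fold higher number from compound 2 to compound 3 (0.25 log units; within the scatter) stays small, so no step beyond the scatter is expected in this assay here. The expected step is a 1.2-fold higher number from compound 3 to compound 4 (0.06 log units; within the scatter) and so remains inside the scatter. For compound 4 an estimated 45 mL.min-1.g-1 is expected, with 22 mL.min-1.g-1 to 85 mL.min-1.g-1 as its range.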

Compound 4, intrinsic clearance in microsomes: < 14 mL.min-1.g-1
Compound 4 gave a limit, no number (the forecaster's own chance of this, stated with the estimate: 2%); middle value at least 3.2-fold (0.50 log units) from the limit.
By their numbers in this assay, from the lowest: compounds 1, 2 and 3 (each within the scatter of the next, the first and the last beyond it). At a limit, below all of these: compound 4.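

In this assay compound 4 gives a limit, not a number: the limit of < 14 mL.min-1.g-1 in this assay, at which 1 of the 4 values shown sits. At this aromatic carbon, the exchange of 1,3-benzothiazol-5-yl for 1-benzothiophen-2-yl gives an at least 2.7-fold lower number from compound 3 to compound 4 (0.44 log units; beyond the scatter), so two bicyclic aromatic groups with the same heavy-atom count are not interchangeable here, in contrast to a 1.8-fold higher number from compound 2 to compound 3 (0.25 log units; within the scatter). The floors against the other two groups, an at least 1.5-fold lower number from compound 2 to compound 4 (0.19 log units; that floor lies within the scatter) and an at least 1.0-fold lower number from compound 1 to compound 4 (0.02 log units; that floor lies within the scatter), settle no order.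

Open, going by these compounds, is whether the nitrogen of the leaving group or the point of attachment carries the step; 1-benzothiophen-5-yl or 1,3-benzothiazol-2-yl at this carbon would separate the two.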